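The source may hold more compounds than are shown below. What is called first, only, known or untested is meant among the compounds shown, and "the series" means these compounds.

Measured compounds:
compound 1, `COc1ccc(/C=C/c2cc(OC)cc(OC)c2/C=C/C(=O)c2ccccc2C)cc1`, 6.1 ug/mL;
compound 2, `COc1ccc(/C=C/c2cc(OC)cc(OC)c2/C=C/C(=O)c2ccc(C)cc2C)cc1`, 4 ug/mL;
compound 3, `COc1ccc(/C=C/c2cc(OC)cc(OC)c2/C=C/C(=O)c2ccc(F)cc2)cc1`, 5.3 ug/mL.

In a functional assay on B16-F10 cells (Mus musculus) for antiproliferative activity, read by MTT assay, with a stated time of 48 h (on this read-out lower numbers stand for stronger inhibition and higher numbers for weaker inhibition), compound 3 stands second highest of the three numbers, with compound 1 nearest at a 1.2-fold lower number from compound 1 to compound 3 (0.06 log units; within the scatter) and compound 2 furthest at a 1.3-fold higher number from compound 2 to compound 3 (0.12 log units; within the scatter). Compound 4, `COc1ccc(/C=C/c2cc(OC)cc(OC)c2/C=C/C(=O)c2ccc(-c3ccccc3)cc2)cc1`, differs from compound 3 by phenyl in place of fluoro on an aromatic carbon. Within the data shown here, no measured step swaps fluoro for phenyl; the steps that bear on changes of the aryl attached to the carbonyl are a 1.2-fold lower number from compound 1 to compound 3 (0.06 log units; within the scatter) and a 1.3-fold higher number from compound 2 to compound 3 (0.12 log units; within the scatter), and the added methyl gave a 1.5-fold lower number from compound 1 to compound 2 (0.18 log units; within the scatter), all within the scatter. A step of a 1.1-fold lower number from compound 3 to compound 4 (0.03 log units; within the scatter) is therefore expected, none beyond the scatter. Compound 4 is estimated at 5 ug/mL, between 2 ug/mL and 12 ug/mL.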

Compound 4, half-maximal inhibitory concentration: 10.6 ug/mL
Compound 4: middle estimate off by 2.1-fold (0.33 log units), on the low side, and the stated range covers the measured number.
By their numbers in this assay, from the lowest: compounds 2, 3, 1 and 4 (each within the scatter of the next, the first and the last beyond it).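

With phenyl in place of fluoro on this aromatic carbon, this assay gives a 2.0-fold higher number from compound 3 to compound 4 (0.30 log units; within the scatter) and so stays within the scatter, as does the change to 4-phenylphenyl from 2-methylphenyl, with a 1.7-fold higher number from compound 1 to compound 4 (0.24 log units; within the scatter) in that comparison. Among these compounds, only 4-phenylphenyl in place of 2,4-dimethylphenyl, with a 2.7-fold higher number from compound 2 to compound 4 (0.42 log units; beyond the scatter) as a modest step, goes beyond the scatter, and it is the first step to do so. The compounds shown leave open how an amine or a carboxylic acid would read at this same aromatic carbon. Nothing given here bears on what lies behind this modest step.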